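This account rests on a few compounds, and the source may have more. Where it says the series, first, only, none or still open, it means among the compounds named here.

Of the compounds shown here, three of one shared core have been tested in an assay on isolated protein for inhibition of phenylalanine--tRNA ligase, mitochondrial (Homo sapiens) (on this read-out higher numbers stand for weaker inhibition and lower numbers for stronger inhibition), so far, and none has given a number. Compound 1 `COc1ccccc1N1C(=O)[C@@H]2C(c3ccccc3C)OC3(C(=O)c4ccccc4C3=O)[C@@H]2C1=O` sits at the limit of this assay, with > 100000 nM. Compound 2 `O=C1[C@@H]2C(c3ccccc3)NC3(Cc4ccccc4C3)[C@@H]2C(=O)N1c1ccc(Cl)c(Cl)c1` likewise returns only the limit, > 100000 nM. Compound 3 `O=C1[C@@H]2C(c3ccccc3)OC3(C(=O)c4ccccc4C3=O)[C@@H]2C(=O)N1c1ccc(Cl)c(C(F)(F)F)c1`, the starting point of the step followed here, also stands at the limit, with > 100000 nM. What these results show is therefore only (the limit of > 100000 nM in this assay, at which 3 of the 3 values shown sit), and compound 3 is indistinguishable from the other two on the numbers shown.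

Compound 4 `Cc1ccc(N2C(=O)[C@@H]3C(c4ccccc4)OC4(C(=O)c5ccccc5C4=O)[C@@H]3C2=O)cc1Cl` differs from compound 3 in one place: 3-chloro-4-methylphenyl in place of 4-chloro-3-(trifluoromethyl)phenyl on an amide-type nitrogen in a ring. The change keeps the rest of the molecule untouched and swaps one substituted phenyl on the amide-type nitrogen in a ring for another.

Among the measured compounds shown here, with no measured step between compounds to lean on, and every value so far at the limit, the expectation is of no step beyond the scatter in this assay: compound 4 is expected to stay where compound 3 is, so the estimated step of a number no higher from compound 3 to compound 4 (the limit leaves the size open) is essentially flat. Compound 4 is thus estimated at 100000 nM, within a range from 30000 nM to 300000 nM, and most likely this assay will once more report only a limit.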

Compound 4, half-maximal inhibitory concentration: > 100000 nM
Compound 4: a limit, no number (the forecaster's own chance of this, stated with the estimate: 85%); the middle value lies on the limit itself.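

Among the compounds shown here, compound 3 and compound 4 both return only a limit in this assay, so no step between them can be read. The compounds shown leave open whether any variation of the shared core, or of the substituted phenyl on its amide-type nitrogen, would give a measurable inhibition value, and one finding stands: the limit of > 100000 nM in this assay, at which 4 of the 4 values shown sit.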